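This account rests on a few compounds, and the source may have more. Where it says the series, first, only, none or still open, it means among the compounds named here.

In an ADME assay on microsomes from liver (Mus musculus) for metabolic stability (a higher number here means that the compound lasts longer, a lower number that the compound disappears faster), compound 2 `CC(C)C(Cc1nnn[nH]1)c1ccc(-c2ccc3cccc(F)c3c2)[nH]c1=O` gives 0.853 h, the higher of the two numbers in hand. Compound 1 `CC(C)C(c1ccc(-c2ccc3cccc(F)c3c2)[nH]c1=O)N1CCNC1=O` gives 0.682 h, and the step of a 1.3-fold higher number from compound 1 to compound 2 (0.10 log units; within the scatter). Compound 3 `CCn1ncc2c(F)cc(-c3ccc(C(CC)(CC)c4nncn4C)c(=O)[nH]3)cc21` reaches only a limit of the assay, > 3 h (the limit of > 3 h in this assay, at which 1 of the 3 values shown sits). Compound 4 `CC(C)C(Cc1noc(=O)[nH]1)c1ccc(-c2ccc3cccc(F)c3c2)[nH]c1=O` has not yet been measured; it differs from compound 2 by a group of 6 heavy atoms (2 carbon, 2 nitrogen, 2 oxygen; one five-membered aromatic ring with 3 hetero atoms) in place of a group of 5 heavy atoms (1 carbon, 4 nitrogen; one five-membered aromatic ring with 4 hetero atoms), on a saturated chain carbon, two bonds along the chain from an aromatic carbon. Among the measured compounds shown here, the only measured step that touches this place is the one from compound 1 to compound 2, which stayed within the scatter, so for compound 4 the expected step is a 1.0-fold lower number from compound 2 to compound 4 (0.00 log units; within the scatter), with no shift beyond the scatter in either direction. Compound 4 is therefore estimated at 0.85 h, in the range 0.4 h to 1.8 h.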

Compound 4, half-life: 2.78 h
The estimate for compound 4 lay 3.3-fold (0.51 log units) below the measured number; the measured number lies above the stated range.
By their numbers in this assay, from the lowest: compounds 1 and 2 (each within the scatter of the next); then compound 4. At a limit, above all of these: compound 3.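

In this assay, this position proves able to move the number after all: the ring swap gives a 3.3-fold higher number from compound 2 to compound 4 (0.51 log units; beyond the scatter), whereas the earlier change here had stayed within the scatter. The new ring also stands clear of the group in compound 1, with a 4.1-fold higher number from compound 1 to compound 4 (0.61 log units; beyond the scatter). The data shown offer no measured explanation for this difference.

The compounds shown leave open whether a carboxylic acid at this place would also raise the number. Among the compounds shown here, they also leave open whether the step would hold on a core other than the one shared by compound 1, compound 2 and compound 4.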